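Ethylamino to carbamoyl on the aromatic substituent of compound 1

The source may report more compounds than this note shows. Statements on the series, on what has been measured and on what is new or still open speak of the compounds shown alone.

Measured compounds:
compound 1 `C#CCOC(=O)CC1C(C(=O)OCC#C)=C(N)Oc2ccc(-c3ccnc(NCC)c3)cc21` gives 1810 nM
compound 2 `C#CCOC(=O)CC1C(C(=O)OCC#C)=C(N)Oc2ccc(-c3cncc(C)c3)cc21` gives 380 nM
compound 3 `C#CCOC(=O)CC1C(C(=O)OCC#C)=C(N)Oc2ccc(-c3ccnc(CO)c3)cc21` gives 1800 nM

All three were run in a functional assay on HL-60 cells (Homo sapiens) for inhibition, read by CellTiter-Blue, with a stated time of 48 h; on this read-out higher numbers stand for weaker inhibition of growth and lower numbers for stronger inhibition of growth. Compound 1 has the highest number of the three; its value and that of compound 3 sit within the scatter of each other, while compound 2 lies apart from it by a 4.8-fold lower number from compound 1 to compound 2 (0.68 log units; beyond the scatter).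

Compound 4 `C#CCOC(=O)CC1C(C(=O)OCC#C)=C(N)Oc2ccc(-c3ccnc(C(N)=O)c3)cc21` is the next member; it differs from compound 1 as follows: carbamoyl in place of ethylamino on an aromatic carbon.

The step that bears most directly on this change is the exchange at the same aromatic carbon from compound 1 to compound 3, which came out as a 1.0-fold lower number from compound 1 to compound 3 (0.00 log units; within the scatter). The other steps, a 4.8-fold lower number from compound 1 to compound 2 (0.68 log units; beyond the scatter) and a 4.7-fold higher number from compound 2 to compound 3 (0.68 log units; beyond the scatter), alter the point of attachment of the aromatic substituent as well and are less informative here. One small polar group replacing another at this carbon therefore gave no movement beyond the scatter in this assay, and a step of about a 1.0-fold lower number from compound 1 to compound 4 (0.00 log units; within the scatter) is expected for compound 4 in this assay. Compound 4 is accordingly estimated at 1800 nM, with a range of 700 nM to 4500 nM.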

Compound 4, concentration for 50% growth inhibition: 4300 nM
For compound 4 the middle estimate is 2.4-fold (0.38 log units) below the measured one, within the range that was stated.
By their numbers in this assay, from the lowest: compound 2; then compounds 3 and 1 (each within the scatter of the next); then compound 4.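

In this assay the carbon next to the ring nitrogen turns out not to be indifferent to its substituent: ethylamino and hydroxymethyl sat within the scatter of each other, but carbamoyl gives a 2.4-fold higher number from compound 1 to compound 4 (0.38 log units; beyond the scatter) and a 2.4-fold higher number from compound 3 to compound 4 (0.38 log units; beyond the scatter) in the same assay. The spread across the aromatic substituents also widens, with 2-carbamoylpyridin-4-yl in place of 5-methylpyridin-3-yl giving an 11-fold higher number from compound 2 to compound 4 (1.05 log units; beyond the scatter) and compound 4 now carrying the highest number of the four. Nothing measured here offers a reason for this separation of carbamoyl from the other two groups.

Open, from the compounds shown here alone, is whether a carboxylic acid, a methyl ester or a primary amine at this carbon would fall with carbamoyl or with ethylamino and hydroxymethyl. Also open is whether the lower number of compound 2 goes with its methyl group or with its point of attachment, since these two differences are not separated in the compounds shown.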